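This account rests on a few compounds, and the source may have more. Where it says the series, first, only, none or still open, it means among the compounds named here.

Measured in a functional assay on OVCAR-8 cells (Homo sapiens) for antiproliferative activity; a higher number here means a weaker inhibitor, a lower number a stronger inhibitor:
- Compound 1 `Cn1ncc(Cl)c1-c1cc(C(=O)N[C@@H]2CNCC[C@H]2c2ccc(C(F)(F)F)cc2)oc1Cl`: 120 nM
- Compound 2 `CC(=O)NCC[C@@H]1C[C@@H](c2ccc(F)c(F)c2)[C@H](NC(=O)c2cc(-c3c(Cl)cnn3C)c(Cl)o2)CN1`: 880 nM
- Compound 3 `Cn1ncc(Cl)c1-c1cc(C(=O)N[C@@H]2CN[C@H](CCN3CCCCC3)C[C@H]2c2ccc(Cl)c(Cl)c2)oc1Cl`: 1660 nM

Compound 3, at 1660 nM here, lies within the usual scatter of compound 2, whose number is 880 nM here. Both sit well clear of compound 1, which has a clearly lower number and so is the stronger inhibitor.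

Compound 4 `Cn1ncc(Cl)c1-c1cc(C(=O)N[C@@H]2CN[C@H](CC(=O)NC3CC3)C[C@H]2c2ccc(Cl)c(Cl)c2)oc1Cl` is compound 3 with one change: cyclopropylcarbamoyl in place of (piperidin-1-yl)methyl on a saturated chain carbon bound to a saturated ring carbon. Cut one bond further out, this reads as 2-(piperidin-1-yl)ethyl to (cyclopropylcarbamoyl)methyl.

Among the measured compounds shown here, no two measured compounds differ in just one place, so nothing here tests this swap directly. The expectation is therefore cautious: a small move towards a lower number, perhaps none beyond the scatter, with compound 2 at 880 nM as the nearest guide. The expected step, a 1.8-fold lower number from compound 3 to compound 4 (0.27 log units; within the scatter), is only an estimate. For compound 4 the estimated value is 900 nM, with an expected range from 300 nM to 2500 nM.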

Compound 4, half-maximal inhibitory concentration: 580 nM
Estimate against measurement, compound 4: 1.6-fold (0.19 log units) above; the measured number falls inside the stated range.
By their numbers in this assay, from the lowest: compound 1; then compounds 4, 2 and 3 (each within the scatter of the next, the first and the last beyond it).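

In this assay, among the compounds shown here, putting cyclopropylcarbamoyl in place of (piperidin-1-yl)methyl on a saturated chain carbon bound to a saturated ring carbon gives a 2.9-fold lower number from compound 3 to compound 4 (0.46 log units; beyond the scatter) and this is the only comparison here that changes a single place. It shows that this chain position does not depend on the six-membered ring and its nitrogen, and that an amide carrying a three-membered carbon ring, with a hydrogen-bond donor the old group lacks, is accepted with a lower number. No measurement shown explains why the number falls.

A single replacement cannot separate the part played by the amide from that of the cyclopropyl ring, and a primary amide, a carboxylic acid or a longer chain ending in the same amide would help to tell them apart. Going by these compounds, whether the swap gives a similar step on a different core also remains open.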